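Pyridin-2-yl for phenyl on the piperazine of compound 2

This account rests on a few compounds, and the source may have more. Where it says the series, first, only, none or still open, it means among the compounds named here.

Of the compounds shown here, two share the saccharin-derived core and have been measured in an assay on HEK293 cells for displacement of a labelled ligand from 5-hydroxytryptamine receptor 7 (Homo sapiens); on this read-out higher numbers stand for weaker inhibition and lower numbers for stronger inhibition. Compound 1 `O=C1c2ccccc2S(=O)(=O)N1CCCCCCN1CCN(c2cccc(Cl)c2Cl)CC1` carries a dichlorophenyl group on the piperazine nitrogen and a six-carbon linker; in this assay compound 1 gives 487 nM. Compound 2 `O=C1c2ccccc2S(=O)(=O)N1CCCCCN1CCN(c2ccccc2)CC1` has an unsubstituted phenyl on that nitrogen and a five-carbon linker; in this assay compound 2 gives 148 nM, the lower of the two numbers, and the number for compound 1 stands above it by more than the usual scatter.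

Compound 3 `O=C1c2ccccc2S(=O)(=O)N1CCCCCN1CCN(c2ccccn2)CC1` differs from compound 2 in one place: pyridin-2-yl in place of phenyl on an amine nitrogen in a ring. Within the data shown here, no pair of measured compounds shows what this exchange does on this read-out, so the direction of the step is not fixed by the data. Among the measured compounds shown here, the expectation is for a modest rise in the number, a 1.9-fold higher number from compound 2 to compound 3 (0.28 log units; within the scatter), because compound 2 at 148 nM is the only anchor and the change keeps ring size and position while introducing one acceptor. Compound 3 is therefore estimated at 280 nM, with a plausible range from 80 nM to 900 nM.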

Compound 3, inhibition constant: 179 nM
Beside the measured number, compound 3's estimate is 1.6-fold (0.19 log units) above it; low and high end bracket the measured number.
By their numbers in this assay, from the lowest: compounds 2 and 3 (each within the scatter of the next); then compound 1.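

In this assay, among these compounds, pyridin-2-yl in place of phenyl on an amine nitrogen in a ring gives a 1.2-fold higher number from compound 2 to compound 3 (0.08 log units; within the scatter) and so provides the first step in this set that differs in one place. At this position, the exchange of one ring carbon for nitrogen, with the hydrogen-bond acceptor that comes with it, produces no difference that this read-out can separate from the scatter of repeated measurements. No measured information at hand speaks to what lies behind this result. 

The compounds shown leave open whether pyridin-3-yl, pyrimidin-2-yl or 2-methoxyphenyl on the same nitrogen would also stay within the scatter of compound 2, and whether pyridin-2-yl would give a similar step on a six-carbon linker. Compound 1 differs from compound 2 in both the group on that nitrogen and the linker, so the step between them cannot be read for either change alone, and the separate contributions of the dichlorophenyl group and the longer chain remain unresolved.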